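Fluoromethyl and Aminomethyl Nucleoside Analogues in a Leukaemia Cell Assay

The source may hold more compounds than are shown below. What is called first, only, known or untested is meant among the compounds shown, and "the series" means these compounds.

Three nucleoside analogues were tested in a functional assay on CCRF-CEM cells (Homo sapiens) for antiproliferative activity, with a stated time of 72 h; a lower number here means that less compound is needed, a higher number that more compound is needed for the effect. Compound 1 `Cc1cn([C@@H]2O[C@H](CO)[C@@H](CF)[C@H]2O)c(=O)[nH]c1=O` carries a fluoromethyl branch on its sugar ring; in this assay compound 1 reaches only the assay limit of > 100 uM. Compound 2 `Cc1cn([C@@H]2O[C@H](CO)[C@@H](CN)[C@H]2O)c(=O)[nH]c1=O` carries an aminomethyl branch in its place, and in this assay compound 2 likewise gives only a limit of > 100 uM. Compound 3 `Cc1cn([C@@H]2O[C@H](CO)[C@@H](CN)[C@@H]2O)c(=O)[nH]c1=O` shares every atom and bond with compound 2 and differs only in how one ring stereocentre is drawn (the two compounds have the same atoms and bonds and differ only in configuration as drawn: 1 of 4 stereo elements differ; a stereocentre at a saturated ring carbon is drawn R in compound 2 and S in compound 3); in this assay compound 3 also stops at the limit of > 100 uM.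

The change from compound 2 to compound 1, (fluoro in place of amino on a saturated chain carbon bound to a saturated ring carbon), gives a step that the two limits leave unreadable from compound 2 to compound 1, and the change in configuration gives a step that the two limits leave unreadable from compound 2 to compound 3; neither step can be sized because of the limit of > 100 uM in this assay, at which 3 of the 3 values shown sit. The two cores of compound 2 and compound 3 differ only in the sense of the fact that compounds 2 and 3 differ only in the configuration as drawn.

Compound 4 `Cc1cn([C@@H]2O[C@H](CO)[C@@H](CF)[C@@H]2O)c(=O)[nH]c1=O` has not yet been measured. It differs from compound 3 by fluoro in place of amino on a saturated chain carbon bound to a saturated ring carbon, at the same place as in the step from compound 2 to compound 1, so this is the same change carried out on the other core. Compound 4 is expected to show a step that the limit leaves unreadable from compound 3 to compound 4, set beside a step that the two limits leave unreadable from compound 2 to compound 1, because the limit of > 100 uM in this assay, at which 3 of the 3 values shown sit, leaves every measured value at the limit and the fluoro-for-amino swap did not pull compound 1 below it. For compound 4 the expected value in this assay is therefore 150 uM, in a range from 50 uM to 500 uM.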

Compound 4, concentration for half-maximal effect: > 100 uM
Compound 4: only a limit was reported; the forecaster's own chance of this, stated with the estimate: 85%; the middle value lies beyond the limit too.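

Going by these compounds alone, no step to compound 4 can be read in this assay, neither from compound 3 nor from compound 1, because the result gives only a limit, as do the others: the limit of > 100 uM in this assay, at which 4 of the 4 values shown sit. The compounds shown leave open how far compound 1, compound 2, compound 3 and compound 4 each lie past that limit, and whether the aminomethyl to fluoromethyl change or the configuration alters the read-out at all.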